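Replacing a difluorophenyl with a nitrophenyl on the acyl side

A few compounds are considered here, and "the series" means these few. Any claim that something is new, unique, unknown or untested is made for them only; others in the source may bear on it.

Of the compounds shown here, three of one shared core have been measured. Compound 1 `CN(C(=O)NC(=O)c1ccc([N+](=O)[O-])cc1)c1nc(C(F)(F)F)c(C(=O)N/N=C/c2ccc([N+](=O)[O-])cc2)s1` gives 8.42 ug/mL in a functional assay on HeLa cells (Homo sapiens) for inhibition, read by MTT assay, with a stated time of 72 h; a higher number here means a weaker inhibitor, a lower number a stronger inhibitor. Compound 2 `CN(C(=O)NC(=O)c1ccc(C(F)(F)F)cc1)c1nc(C(F)(F)F)c(C(=O)N/N=C/c2cccc(C(F)(F)F)c2)s1` gives 6.2 ug/mL in this assay, and compound 3 `CN(C(=O)NC(=O)c1ccc(F)c(F)c1)c1nc(C(F)(F)F)c(C(=O)N/N=C/c2cccc(C(F)(F)F)c2)s1` gives 4.21 ug/mL in this assay, the lowest of the three numbers, though both neighbours sit within the scatter of it. Within the data shown here, the only single-point step among them, a 1.5-fold lower number from compound 2 to compound 3 (0.17 log units; within the scatter), is itself within the scatter.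

Compound 4 `CN(C(=O)NC(=O)c1ccc([N+](=O)[O-])cc1)c1nc(C(F)(F)F)c(C(=O)N/N=C/c2cccc(C(F)(F)F)c2)s1` has not yet been measured. It differs from compound 3 by 4-nitrophenyl in place of 3,4-difluorophenyl on a carbonyl carbon. Among the measured compounds shown here, no measured step covers this exact exchange; the step from compound 2 to compound 3 changed the same carbonyl-bound ring and barely moved the number, while compound 1, which carries the 4-nitrophenyl on that carbonyl but differs from compound 4 on the hydrazone side, gave the highest number of the three. On this basis a small rise in this assay is expected, a 1.4-fold higher number from compound 3 to compound 4 (0.15 log units; within the scatter), still within the scatter. Compound 4 is therefore estimated at 6 ug/mL, with a range from 3 ug/mL to 12 ug/mL.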

Compound 4, half-maximal inhibitory concentration: 4.12 ug/mL
For compound 4 the middle estimate is 1.5-fold (0.16 log units) above the measured one, and the stated range covers the measured number.
By their numbers in this assay, from the lowest: compounds 4, 3, 2 and 1 (each within the scatter of the next, the first and the last beyond it).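

In this assay, 4-nitrophenyl in place of 3,4-difluorophenyl on the carbonyl carbon does not separate the two compounds, a 1.0-fold lower number from compound 3 to compound 4 (0.01 log units; within the scatter), and nitro in place of trifluoromethyl on an aromatic carbon does not either, a 1.5-fold lower number from compound 2 to compound 4 (0.18 log units; within the scatter), so all three rings on this carbonyl lie within the scatter of one another. Among these compounds, the only step beyond the scatter, and a modest one, comes at a different place, with 3-(trifluoromethyl)phenyl in place of 4-nitrophenyl on a carbon with a double bond to nitrogen, a 2.0-fold lower number from compound 1 to compound 4 (0.31 log units; beyond the scatter); the higher number of compound 1 therefore goes with that exchange, not with the 4-nitrophenyl on the carbonyl. Nothing available bears on why these rings read alike.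

Still open, going by these compounds, is whether this carbonyl carbon would give a similar number with a ring carrying an amine or a carboxylic acid, or with a cyclohexyl ring in place of the phenyl. On these data alone, it is also open whether the step at the carbon with a double bond to nitrogen would be of similar size with 3,4-difluorophenyl on the carbonyl.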